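Swapping an alkylamino group on a small pyridazinone core

The source may hold more compounds than are shown below. What is called first, only, known or untested is meant among the compounds shown, and "the series" means these compounds.

Measured so far:
compound 1, `CCOc1c(NC)cnn(C)c1=O`: 4.5%
compound 2, `CCCNc1cnn(C)c(=O)c1OCC`: 8%

Both compounds were tested in a functional assay on the whole organism (strain Wistar) for inhibition, with Rattus norvegicus as the target, read by paw edema, with stated times of 30 min and 3 h, at a dose of 50 mg/kg by the oral route; a lower number here means a weaker effect, a higher number a stronger effect of the compound at the dose given. Compound 1 gives 4.5% and compound 2 gives 8%; the two numbers lie within the usual scatter of each other, so neither can be called stronger. Among the compounds with values here, the only step measured so far, a number 3.5 percentage points higher from compound 1 to compound 2 (within the scatter), is therefore a change that made no real difference to the read-out.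

Compound 3, `CCOc1c(N(C)C)cnn(C)c1=O`, has not yet been measured. It differs from compound 2 at the same nitrogen that was varied before: dimethylamino in place of propylamino on an aromatic carbon. The measured step is related, since it also altered what sits on this nitrogen, and it stayed within the scatter. Nothing measured points to a move beyond the scatter for the new change either.

Compound 3 is thus expected to give 6% in this assay, within the range 0% to 15%. The step of a number 2 percentage points lower from compound 2 to compound 3 (within the scatter) is estimated to be no larger than the scatter, because a number 3.5 percentage points higher from compound 1 to compound 2 (within the scatter) was itself within it.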

Compound 3, a percentage reported as inhibition, in the whole organism at one dose (the size of the read-out at that dose, not a potency): 30.7%
Estimate against measurement, compound 3: 24.7 percentage points below, and the stated range ends below it.
By their numbers in this assay, from the lowest: compounds 1 and 2 (each within the scatter of the next); then compound 3.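

The nitrogen on the aromatic carbon turns out to be a sensitive spot: what it carries can move the read-out well beyond the scatter, which the swap between compound 1 and compound 2 gave no sign of. In this assay, the change from propylamino to dimethylamino appears as a number 22.7 percentage points higher from compound 2 to compound 3 (beyond the scatter) and the added methyl on the nitrogen as a number 26.2 percentage points higher from compound 1 to compound 3 (beyond the scatter), so both routes to compound 3 lead to a clear rise. Within the data shown here, the nitrogen keeps a hydrogen in compound 1 and compound 2 and has none in compound 3, and that is the one feature setting compound 3 apart, though no measurement here explains the rise.

These compounds leave open whether the gain comes from having two alkyl groups on this nitrogen in general or from dimethylamino in particular, and a diethylamino or a methylpropylamino group at this position would help to separate the two. The plain amino group, with no alkyl group on the nitrogen, also remains an open comparison, and all these readings come from a single dose, so they describe the size of the effect at that dose and not potency.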